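This account rests on a few compounds, and the source may have more. Where it says the series, first, only, none or still open, it means among the compounds named here.

Compound 3 `Cn1nc(Cc2nnc(SCCCCCCCC(=O)Nc3ccc(Cl)cc3Cl)n2CCCO)c2ccccc2c1=O` carries a 3-hydroxypropyl group on an aromatic nitrogen of the shared core. In an assay on NK92 cells for inhibition of interleukin-15 (Homo sapiens), read by AlphaScreen, with stated times of 30 min and 1 h (a higher number here means a weaker inhibitor, a lower number a stronger inhibitor), compound 3 gives > 30000 nM, which is a limit of the assay and not a number (the limit of > 30000 nM in this assay, at which 1 of the 3 values shown sits). Its two measured neighbours both sit well inside the assay range: compound 1 `Cn1nc(Cc2nnc(SCCCCCCCC(=O)Nc3ccc(Cl)cc3Cl)n2CCC=O)c2ccccc2c1=O`, which bears a 2-formylethyl group at the same nitrogen, gives 710 nM in this assay, and compound 2 `Cn1nc(Cc2nnc(SCCCCCCCC(=O)Nc3ccc(Cl)cc3Cl)[nH]2)c2ccccc2c1=O`, with hydrogen there, gives 280 nM. The step of a 2.5-fold lower number from compound 1 to compound 2 (0.40 log units; beyond the scatter) is modest, whereas an at least 42-fold higher number from compound 1 to compound 3 (1.62 log units; beyond the scatter) and an at least 100-fold higher number from compound 2 to compound 3 (2.02 log units; beyond the scatter) are both large, so the hydroxymethyl terminus of compound 3 is the only substituent here that pushes the value past the range of this assay.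

Compound 4 `Cn1nc(Cc2nnc(SCCCCCCCC(=O)Nc3ccc(Cl)cc3Cl)n2CCC(=O)O)c2ccccc2c1=O` is compound 3 with carboxy in place of hydroxymethyl on a saturated chain carbon, two bonds along the chain from an aromatic nitrogen. Among the compounds with values here, no measured step tests a carboxy at this place, and because compound 3 gives > 30000 nM as a limit, the size of the step to compound 4 cannot be read from a finished number. Compound 4 is therefore expected to stay near the weak end of this assay, at an estimated 25000 nM, between 3000 nM and 80000 nM. The step this estimate implies is an at least 1.2-fold lower number from compound 3 to compound 4 (0.07 log units; that floor lies within the scatter), with a fair chance that this assay again reports only a limit.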

Compound 4, half-maximal inhibitory concentration: 9500 nM
For compound 4 the middle estimate is 2.6-fold (0.42 log units) above the measured one; measured number inside the range.
By their numbers in this assay, from the lowest: compound 2; then compound 1; then compound 4. At a limit, above all of these: compound 3.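

Carboxy at this chain end gives a reading inside the range of this assay, with an at least 3.1-fold lower number from compound 3 to compound 4 (0.49 log units; beyond the scatter), which shows that the end group, and not the presence of a chain on the aromatic nitrogen alone, decides whether the value stays measurable. The carboxy group still does not match the other two compounds, with a 34-fold higher number from compound 2 to compound 4 (1.53 log units; beyond the scatter) and a 13-fold higher number from compound 1 to compound 4 (1.13 log units; beyond the scatter), so among the three chains of this length only the 2-formylethyl group stays close to hydrogen on this nitrogen, and a change from formyl to carboxy costs far more than the step from hydrogen to 2-formylethyl. Compound 3 remains a limit and not a number, so the step leading away from it is only a floor and the true gap at this end of the chain stays unknown: the limit of > 30000 nM in this assay, at which 1 of the 4 values shown sits.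

The compounds shown leave open how an amine, a primary amide or a methyl ester would read at the same chain end, and whether a shorter or longer chain carrying carboxy would move the value in either direction. They also leave open whether any group on this nitrogen can give a lower number than hydrogen does.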